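A few compounds are considered here, and "the series" means these few. Any claim that something is new, unique, unknown or untested is made for them only; others in the source may bear on it.

Measured so far:
compound 1, `O=C1CCCCC/C1=C\c1ccccc1`, > 50000 nM
compound 2, `COc1cccc(/C=C2\CCCCCC2=O)c1`, 50000 nM

In a functional assay on P388 cells (Mus musculus) for inhibition (a lower number here means a stronger inhibitor, a higher number a weaker inhibitor), compound 1 gives only a limit, > 50000 nM, and not a number. Compound 2 keeps the core of compound 1 and carries a methoxy in place of hydrogen on an aromatic carbon; in this assay compound 2 gives 50000 nM. The step of a number no higher from compound 1 to compound 2 (the limit leaves the size open) can not be given a size, because compound 1 sits at the limit of > 50000 nM in this assay, at which 1 of the 2 values shown sits. Where compound 1 stands on the numbers is therefore known only as a limit; it is a weak inhibitor, and how weak stays open.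

Compound 3, `CN(C)c1ccc(/C=C2\CCCCCC2=O)cc1`, has not yet been measured in this assay. It differs from compound 1 in one place: dimethylamino in place of hydrogen on an aromatic carbon. Within the data shown here, the only measured step that bears on this change is the one from compound 1 to compound 2, which also exchanges hydrogen for another group on an aromatic carbon; its size is not readable, so it gives no guide to direction or size beyond the scatter. Compound 3 is thus expected to remain weak, at about 50000 nM in this assay, with a range from 15000 nM to 200000 nM. The step of a number no higher from compound 1 to compound 3 (the limit leaves the size open) that this estimate means is expected to lie within the scatter.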

Compound 3, half-maximal inhibitory concentration: 18800 nM
The estimate for compound 3 lay 2.7-fold (0.42 log units) above the measured number; measured number inside the range.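

In this assay dimethylamino on an aromatic carbon, para to a group of 9 heavy atoms, gives an at least 2.6-fold lower number from compound 1 to compound 3 (0.42 log units; beyond the scatter) and is thus a change on the six-membered aromatic ring of carbon only whose effect can be read as lying beyond the scatter. Among these compounds, the step from compound 1 to compound 2 cannot be read, so only this step shows that replacing hydrogen on this ring can lower the number relative to compound 1. The size of the step is only a minimum, because compound 1 stands at a limit: the limit of > 50000 nM in this assay, at which 1 of the 3 values shown sits.

The compounds shown leave open whether the lower number belongs to dimethylamino itself or would also come with another amine, such as diethylamino or a plain amino group, or with methoxy at this same place. They also leave open how far compound 3 truly lies from compound 1, and whether a carboxylic acid or a longer chain at this place would change the number in the same direction.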